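This account rests on a few compounds, and the source may have more. Where it says the series, first, only, none or still open, it means among the compounds named here.

Working notes on the series.

Three compounds have been run in an assay on isolated protein for inhibition of serine/threonine-protein kinase Chk2 (Homo sapiens), read by mobility shift assay, tested at 30 uM; a higher number here means more inhibition at the concentration tested (going by the name of the read-out), a lower number less inhibition. Compound 1 `COc1ccc(-c2cc3[nH]nc(N)c3c(=O)[nH]2)cc1` gives 43%. Compound 2 `Cn1nc(N)c2c(=O)[nH]c(-c3ccccc3)cc21` gives 16%. Compound 3 `Cn1nc(N)c2c(=O)[nH]c(-c3ccccn3)cc21` gives 25%. On these numbers compound 2 stands lowest of the three; the nearest is compound 3, whose step a number 9 percentage points higher from compound 2 to compound 3 (within the scatter) lies within the scatter, while compound 1 sits further off, beyond the scatter. Among the measured compounds shown here, compound 1 and compound 2 differ in two places at once, so their two values show only that the pair with the methoxy group and the unmethylated core reads higher; no single-change step separates them.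

The next compound, compound 4 `COc1ccc(-c2cc3c(c(N)nn3C)c(=O)[nH]2)cc1`, changes compound 2 in one place: methoxy in place of hydrogen on an aromatic carbon

For the measured compounds named here, no measured step covers this change. Going by the values given here, the only step in hand, from compound 2 to compound 3, swaps the aryl ring itself and does not bear on a methoxy substituent. The higher reading of compound 1, which carries the same methoxy group, is the only hint and is confounded by the second difference. The expectation is therefore a small rise in this assay, perhaps not beyond the scatter, with wide uncertainty: the step of a number 12 percentage points higher from compound 2 to compound 4 (beyond the scatter) is an estimate only. Compound 4 is expected to give about 28%, within 12% to 48%.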

Compound 4, a percentage reported as inhibition, at one concentration (the size of the read-out at that concentration, not a potency): 16%
Compound 4: middle estimate off by 12 percentage points, on the high side; the measured number falls inside the stated range.
By their numbers in this assay, from the lowest: compounds 2, 4 and 3 (each within the scatter of the next); then compound 1.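

In this assay, methoxy in place of hydrogen on the six-membered aromatic ring of carbon only, para to a large group, gives no change at the digits printed from compound 2 to compound 4 (within the scatter), so with the methyl on the aromatic nitrogen in place, this position shows no response to this change at the single concentration tested. Among the compounds shown here, compound 4 also separates the two differences that were tangled between compound 1 and compound 2: with the methoxy group held constant, methyl in place of hydrogen on an aromatic nitrogen gives a number 27 percentage points lower from compound 1 to compound 4 (beyond the scatter), and this is the only single change so far that reaches beyond the scatter. Nothing in hand explains either step, and the numbers record only the size of each reading.

As far as these compounds go, it remains open whether the methyl step has the same size with the phenyl or pyridin-2-yl ring in place of the methoxy-bearing ring, and whether methoxy has any effect on the core of compound 1. Also open, from the compounds shown here alone, is whether an amine or a carboxylic acid at the methoxy position, or an ethyl group in place of the methyl on the aromatic nitrogen, would move the reading.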